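Swapping the ring on a sulfonamide nitrogen

The source may hold more compounds than are shown below. What is called first, only, known or untested is meant among the compounds shown, and "the series" means these compounds.

Compound 1 `C=C1CC[C@@H]2[C@](C)(COC(C)=O)[C@H](OC(C)=O)CC[C@@]2(C)[C@H]1CC(Nc1ccc(S(=O)(=O)Nc2nccs2)cc1)C1=CCOC1=O` and compound 2 `C=C1CC[C@@H]2[C@](C)(COC(C)=O)[C@H](OC(C)=O)CC[C@@]2(C)[C@H]1CC(Nc1ccc(S(=O)(=O)Nc2ncccn2)cc1)C1=CCOC1=O` share one core and differ only in the ring attached on a sulfonamide nitrogen. Among the compounds with values here, in a functional assay on SF-539 cells (Homo sapiens) for inhibition, read by sulforhodamine B assay, with a stated time of 48 h (a lower number here means that less compound is tolerated, a higher number that more compound is tolerated), compound 1 gives 23500 nM, the highest of the two numbers known, while compound 2 gives 5780 nM; the step of a 4.1-fold lower number from compound 1 to compound 2 (0.61 log units; beyond the scatter) is the only measured change so far. Compound 3 `C=C1CC[C@@H]2[C@](C)(COC(C)=O)[C@H](OC(C)=O)CC[C@@]2(C)[C@H]1CC(Nc1ccc(S(=O)(=O)Nc2cc(C)on2)cc1)C1=CCOC1=O` carries a different swap at the same place: 5-methyl-1,2-oxazol-3-yl in place of 1,3-thiazol-2-yl on a sulfonamide nitrogen. Within the data shown here, since the one earlier swap lowered the number, a downward step of similar size is expected, a 2.6-fold lower number from compound 1 to compound 3 (0.42 log units; beyond the scatter). Compound 3 is therefore estimated at 9000 nM, within 3000 nM to 30000 nM.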

Compound 3, concentration lethal to 50% of the cells: 5890 nM
Beside the measured number, compound 3's estimate is 1.5-fold (0.18 log units) above it, within the range that was stated.
By their numbers in this assay, from the lowest: compounds 2 and 3 (each within the scatter of the next); then compound 1.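

A second replacement of 1,3-thiazol-2-yl gives a 4.0-fold lower number from compound 1 to compound 3 (0.60 log units; beyond the scatter) in this assay and so the lower number is not tied to pyrimidin-2-yl alone. Set against each other, the two replacements give a 1.0-fold higher number from compound 2 to compound 3 (0.01 log units; within the scatter) and so cannot be separated here, although their rings differ. Nothing available explains why both part from 1,3-thiazol-2-yl in this way.

As far as these compounds go, whether this position needs a ring at all stays open. A methyl group or a longer alkyl chain on the sulfonamide nitrogen would help to answer that.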